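Dropping the chloro from a weak hydrazone

The source may report more compounds than this note shows. Statements on the series, on what has been measured and on what is new or still open speak of the compounds shown alone.

Compounds measured so far:
compound 1, `CCCSc1nc(N/N=C/c2ccc(Cl)cc2)c2nnn(Cc3ccccc3)c2n1`: > 64000 nM
compound 2, `CCCSc1nc(N/N=C(\C)c2ccc(OC)cc2)c2nnn(Cc3ccccc3)c2n1`: 44300 nM
compound 3, `C#CCSc1nc(N/N=C(\C)c2ccccc2O)c2nnn(Cc3ccccc3)c2n1`: 3820 nM

Of the compounds shown here, three sharing one core have been tested in a functional assay on MGC-803 cells (Homo sapiens) for antiproliferative activity, read by MTT assay, with a stated time of 72 h; on this read-out higher numbers stand for weaker inhibition and lower numbers for stronger inhibition. Compound 1 reaches no number in this assay: its result is the limit > 64000 nM, meaning the assay could not resolve a concentration. In the same assay compound 2 gives 44300 nM, and compound 3 gives 3820 nM. Of the three values shown, then, one sits at the limit of the measurement (the limit of > 64000 nM in this assay, at which 1 of the 3 values shown sits), and that one belongs to compound 1, so compound 1 stands at the edge of what this assay can report.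

Compound 4, `CCCSc1nc(N/N=C/c2ccccc2)c2nnn(Cc3ccccc3)c2n1`, has not yet been measured. It differs from compound 1 in a single place: hydrogen in place of chloro on an aromatic carbon. Going by the values given here, because no pair of measured compounds differs in only one place, there is no measured step to set an expectation against, so the size of the step from compound 1 to compound 4 is open. A change this small, hydrogen in place of chloro on an aromatic carbon, is expected to move the result little, likely within the scatter of this assay, if at all. Compound 4 is therefore expected to give about 70000 nM, between 25000 nM and 200000 nM, with the step that the limit leaves unreadable from compound 1 to compound 4 expected to be small, and a good chance that this assay again reports only a limit for compound 4.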

Compound 4, half-maximal inhibitory concentration: > 64000 nM
Compound 4 ended at the assay's limit; the forecaster's own chance of this, stated with the estimate: 60%; the middle value does not contradict the limit.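

Compound 1 and compound 4 both end at a limit in this assay, not at a number, so no step can be read between them, and hydrogen in place of chloro shows no measurable effect: the limit of > 64000 nM in this assay, at which 2 of the 4 values shown sit.

The compounds shown leave open whether 4-chlorophenyl and phenyl differ in activity at all, and if so, by how much.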